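The compounds below may be only part of what the source reports. "The series", "measured", "known", "first", "only" and "open" are said of these compounds alone.

Three compounds share one core, and all three were measured in an assay on CHO-TREX cells for antagonist activity at transient receptor potential cation channel subfamily A member 1 (Homo sapiens), read by FLIPR and calcium flux, with a stated time of 10 min; a higher number here means a weaker inhibitor, a lower number a stronger inhibitor. Compound 1 `CC(C)(C)c1ccccc1-c1ccc2[nH]ncc2c1` gives 3400 nM. Compound 2 `FC(F)(F)c1ccccc1-c1ccc2[nH]ncc2c1` gives 164 nM. Compound 3 `FC(F)(F)Oc1ccccc1-c1ccc2[nH]ncc2c1` gives 3430 nM. Compound 2 stands lowest of the three, with a 21-fold lower number from compound 1 to compound 2 (1.32 log units; beyond the scatter) and, from the other side, a 21-fold higher number from compound 2 to compound 3 (1.32 log units; beyond the scatter); compound 1 and compound 3 sit close together, with a 1.0-fold higher number from compound 1 to compound 3 (0.00 log units; within the scatter).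

Compound 4 `CC(C)c1cc2[nH]ncc2cc1-c1ccccc1C(F)(F)F` departs from compound 2 by isopropyl in place of hydrogen on an aromatic carbon. Within the data shown here, every measured step so far concerns the group on the pendant phenyl ring, which is held as trifluoromethyl in both compound 2 and compound 4; no measured step touches the fused core where the new group sits. The large steps among compounds 1, 2 and 3 therefore say nothing direct about this change. With no guidance from this assay, the most defensible expectation is that compound 4 stays near compound 2, within or only modestly beyond the usual scatter, and the direction cannot be called from the data. Compound 4 is estimated at 250 nM, in a range from 60 nM to 1000 nM, which means an expected step of a 1.5-fold higher number from compound 2 to compound 4 (0.18 log units; within the scatter).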

Compound 4, half-maximal inhibitory concentration: 25400 nM
For compound 4 the middle estimate is 100-fold (2.01 log units) below the measured one, outside the stated range (above it).
By their numbers in this assay, from the lowest: compound 2; then compounds 1 and 3 (each within the scatter of the next); then compound 4.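

Adding isopropyl to the shared core, on the aromatic carbon ortho to a large group, costs a great deal of activity in this assay, with a 150-fold higher number from compound 2 to compound 4 (2.19 log units; beyond the scatter). Among these compounds, the earlier large steps, such as a 21-fold higher number from compound 2 to compound 3 (1.32 log units; beyond the scatter), all came from changing the group on the pendant phenyl ring, so this result is the first to show that the fused core is also highly sensitive to substitution: here, the hydrogen at this position cannot be replaced by isopropyl without a heavy loss, even with trifluoromethyl held constant on the pendant ring. No measurement offered here accounts for this loss, so the result records its size and place but not its origin.

Hydrogen and isopropyl are the only two groups shown at this position, which leaves open whether a methyl, a fluorine atom, a methoxy or an amine there would stay close to compound 2 or lose as much as compound 4 does. From the compounds shown here alone, it also remains open whether isopropyl would carry the same penalty with tert-butyl or trifluoromethoxy on the pendant ring, or whether it would do so on the other aromatic carbons of the core.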